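A few compounds are considered here, and "the series" means these few. Any claim that something is new, unique, unknown or untested is made for them only; others in the source may bear on it.

Measured so far in a functional assay on PC-3 cells (Homo sapiens) for cytotoxicity, read by MTT assay, with a stated time of 72 h; on this read-out higher numbers stand for weaker inhibition and lower numbers for stronger inhibition:
Compound 1 `O=C(Nc1ccc(Oc2ccnc3[nH]ccc23)cc1)c1nn(-c2ccc(Br)cc2)ccc1=O` gives 8040 nM.
Compound 2 `O=C(Nc1ccc(Oc2ccnc3[nH]ccc23)cc1)c1nn(-c2ccccc2)ccc1=O` gives 15000 nM.
Compound 3 `Cn1ccc2c(Oc3ccc(NC(=O)c4nn(-c5ccc(Br)cc5)ccc4=O)cc3F)ccnc21` gives > 60000 nM, which is a limit of the assay and not a number.

Compound 1 and compound 2 share one core and differ by hydrogen in place of bromo on an aromatic carbon. That change made a 1.9-fold higher number from compound 1 to compound 2 (0.27 log units; within the scatter). Compound 3 rests on another core; the difference between the two cores is not broken down here. Compound 4 `Cn1ccc2c(Oc3ccc(NC(=O)c4nn(-c5ccccc5)ccc4=O)cc3F)ccnc21` is not yet measured and differs from compound 3 by the same change, (hydrogen in place of bromo on an aromatic carbon). Because compound 3 already sits at the limit of > 60000 nM in this assay, at which 1 of the 3 values shown sits, and because the same change gave only a 1.9-fold higher number from compound 1 to compound 2 (0.27 log units; within the scatter), little movement is expected. For compound 4 the expected step is a step that the limit leaves unreadable from compound 3 to compound 4. Compound 4 is estimated at 90000 nM and would most likely again be reported only as a limit.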

Compound 4, half-maximal inhibitory concentration: > 60000 nM
Compound 4: a limit, no number; the forecaster's own chance of this, stated with the estimate: 85%; the middle value lies beyond the limit too.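

Within the data shown here, compound 3 and compound 4 both stand at a limit and not at a number, so no step between them can be read: the limit of > 60000 nM in this assay, at which 2 of the 4 values shown sit. The compounds shown leave open how far going from 4-bromophenyl to phenyl moves the number on the core of compound 3.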